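The source may hold more compounds than are shown below. What is called first, only, known or untested is meant among the compounds shown, and "the series" means these compounds.

Measured in a functional assay on HCT-116 cells (Homo sapiens) for inhibition, read by sulforhodamine B assay, with a stated time of 48 h, tested at 50 uM; on this read-out lower numbers stand for less inhibition of growth and higher numbers for more inhibition of growth at the one concentration tested:
- compound 1 `COc1cccc(/C=C/C(=O)/C=C/c2ccc(OCc3cn(CCCCOc4cc(=O)oc5ccccc45)nn3)c(OC)c2)c1`: 44%
- compound 2 `COc1cc(/C=C/C(=O)/C=C/c2ccccc2)ccc1OCc1cn(CCCCOc2cc(=O)oc3ccccc23)nn1`: 34%
- compound 3 `COc1cc(/C=C/C(=O)/C=C/c2ccco2)ccc1OCc1cn(CCCCOc2cc(=O)oc3ccccc23)nn1`: 47%

Compound 3 sits level with one neighbour, a number 3 percentage points higher from compound 1 to compound 3 (within the scatter), and apart from the other, a number 13 percentage points higher from compound 2 to compound 3 (beyond the scatter). Compound 4 `COc1cc(/C=C/C(=O)/C=C/c2cc(OC)c(OC)c(OC)c2)ccc1OCc1cn(CCCCOc2cc(=O)oc3ccccc23)nn1` differs from compound 3 by 3,4,5-trimethoxyphenyl in place of furan-2-yl on a double-bonded chain carbon bound to a double-bonded chain carbon. The same two steps bear on this change, read in reverse, since both bring in furan-2-yl at this place. Compound 1, with its 3-methoxyphenyl, is the closer precedent, and the methoxy exchange, a number 10 percentage points lower from compound 1 to compound 2 (within the scatter), also stays within the scatter. The expected step is small and downward, not beyond the scatter: a number 5 percentage points lower from compound 3 to compound 4 (within the scatter). For compound 4 the estimated value is 42%, with an expected range of 28% to 56%.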

Compound 4, percent growth inhibition at one concentration: 63%
Compound 4: middle estimate off by 21 percentage points, on the low side; the measured number lies above the stated range.
By their numbers in this assay, from the lowest: compounds 2, 1 and 3 (each within the scatter of the next, the first and the last beyond it); then compound 4.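

At this place on the chain, in this assay, 3,4,5-trimethoxyphenyl separates from every earlier group: the steps of a number 16 percentage points higher from compound 3 to compound 4 (beyond the scatter) and a number 19 percentage points higher from compound 1 to compound 4 (beyond the scatter) and a number 29 percentage points higher from compound 2 to compound 4 (beyond the scatter) all lie clear of the scatter. Among the compounds shown here, the earlier exchange a number 10 percentage points lower from compound 1 to compound 2 (within the scatter) gave no sign of a step this size from methoxy substitution on this ring. No measurement in hand accounts for the rise.
On these data alone, it remains open whether the rise needs all the methoxy groups of 3,4,5-trimethoxyphenyl. As far as these compounds go, it is also open whether an aromatic ring carrying an amine or a carboxylic acid at this place would hold the level of compound 4.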